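Adding a Methyl to a Compound Already at the Assay Limit

The source may report more compounds than this note shows. Statements on the series, on what has been measured and on what is new or still open speak of the compounds shown alone.

Of the compounds shown here, three sharing one core have been tested in an assay on isolated protein for inhibition of thyroid hormone receptor alpha (Homo sapiens), read by fluorescence polarization; on this read-out lower numbers stand for stronger inhibition and higher numbers for weaker inhibition. Compound 1 `CS(=O)(=O)c1ccc(C(=O)N2CCC(C(=O)N(Cc3ccccc3)c3ccccc3)CC2)cc1[N+](=O)[O-]` gives > 60000 nM, which is a limit of the assay rather than a number. Compound 3 `CN(CC(=O)N(Cc1ccccc1)Cc1ccccc1)C(=O)c1ccc(S(C)(=O)=O)c([N+](=O)[O-])c1` gives > 60000 nM, again a limit. Compound 2 `CS(=O)(=O)c1ccc(C(=O)NCCC(=O)N2CCCCC2)cc1[N+](=O)[O-]` gives > 60000 nM, also a limit. Where compound 2 stands can thus be said only loosely, since (the limit of > 60000 nM in this assay, at which 3 of the 3 values shown sit).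

Compound 4 `CC1CCN(C(=O)CCNC(=O)c2ccc(S(C)(=O)=O)c([N+](=O)[O-])c2)CC1` differs from compound 2 by methyl in place of hydrogen on a saturated ring carbon, a methyl in place of hydrogen on a saturated ring carbon. Going by the values given here, no step between measured compounds exists to lean on, and with compound 2 at a limit, no change beyond the usual scatter is expected. Compound 4 is estimated at 80000 nM, with a range from 30000 nM to 250000 nM. The expected change is a step that the limit leaves unreadable from compound 2 to compound 4, meaning none beyond the scatter.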

Compound 4, half-maximal inhibitory concentration: > 60000 nM
Compound 4 was reported as a limit (the forecaster's own chance of this, stated with the estimate: 85%); the middle value does not contradict the limit.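

Going by these compounds alone, compound 2 and compound 4 are both reported only as limits, not as numbers, so no step between them can be read. The compounds shown leave open what methyl in place of hydrogen does here, and whether any compound with this shared core gives a measurable value.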